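Swapping a carbamate for a benzyl ether on a triazole scaffold

The compounds below may be only part of what the source reports. "The series", "measured", "known", "first", "only" and "open" are said of these compounds alone.

Three compounds share a triazole-bearing core and were tested in an assay on nucleic acid for inhibition of Nucleic Acid, read by fluorescence, tested at 100 uM; on this read-out lower numbers stand for less inhibition and higher numbers for more inhibition at the one concentration tested (going by the name of the read-out). Compound 1, `CCCCN(CCCC)Cc1cn(CC(O)COC(=O)NCc2ccccc2)nn1`, gives 42% in this assay. Compound 2, `CCCCNC(=O)OCC(O)Cn1cc(CN2CCCC(C(=O)OCC)C2)nn1`, gives 24% in this assay. Compound 3, `O=C(NCc1ccccc1)OCC(O)Cn1cc(CN2CCC(c3ccccc3)CC2)nn1`, gives 29% in this assay. Compound 2 carries the lowest of the three numbers; the value of compound 3 lies within the scatter of it, while the value of compound 1 lies beyond the scatter, higher. Within the data shown here, no pair of these three differs in a single place, so no single step can be read from them.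

Compound 4, `CCOC(=O)C1CCCN(Cc2cn(CC(O)COCc3ccccc3)nn2)C1`, has not been measured. It differs from compound 2 in one place: benzyl in place of butylcarbamoyl on an oxygen on a saturated carbon. The leaving group brings one hydrogen-bond donor and one hydrogen-bond acceptor; the entering group brings none. Among the measured compounds shown here, with no measured step of this kind to lean on, the change is expected to give a step of a number 5 percentage points higher from compound 2 to compound 4 (within the scatter) that stays within the scatter. Compound 4 is therefore estimated at 29%, between 14% and 46%.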

Compound 4, a percentage reported as inhibition, at one concentration (the size of the read-out at that concentration, not a potency): 26%
Estimate against measurement, compound 4: 3 percentage points above; the range from low to high includes it.
By their numbers in this assay, from the lowest: compounds 2, 4 and 3 (each within the scatter of the next); then compound 1.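

In this assay, this position, on an oxygen on a saturated carbon, now has its first single-place step: benzyl in place of butylcarbamoyl gives a number 2 percentage points higher from compound 2 to compound 4 (within the scatter). With the rest of compound 2 held fixed, a group with one hydrogen-bond donor and one hydrogen-bond acceptor was exchanged for one with neither, and the read-out does not separate the two groups. Nothing measured here offers an explanation for this outcome.

From the compounds shown here alone, this is a single pair, so it remains open whether the same exchange would leave the read-out within the scatter on the other groups carried by compound 1 or compound 3. Also open, going by these compounds, is what a free hydroxyl, a longer alkyl chain or a chain ending in an amine or a carboxylic acid would give on this oxygen.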